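Benzylamine variants of the diamino core: compound 3 to compound 4

A few compounds are considered here, and "the series" means these few. Any claim that something is new, unique, unknown or untested is made for them only; others in the source may bear on it.

Working notes on the series built around the shared core of compound 1 `Nc1cc(N)c2nc(-c3ccccc3)c(Oc3ccc(Cl)c(Cl)c3)nc2c1`. In a functional assay on SF-295 cells (Homo sapiens) for inhibition, read by sulforhodamine B assay, with a stated time of 48 h (a higher number here means a weaker inhibitor of growth, a lower number a stronger inhibitor of growth), compound 1 gives 13800 nM. Compound 2 `CCOC(=O)[C@H](CCC(=O)O)NC(=O)c1ccc(CNc2nc3cc(N)cc(N)c3nc2-c2ccccc2)cc1` carries the longer ester-bearing side chain; in this assay compound 2 returns only a limit, < 100000 nM. Compound 3 `Nc1cc(N)c2nc(-c3ccccc3)c(NCc3ccc(Cl)c(Cl)c3)nc2c1` has the 3,4-dichlorophenyl group on a saturated chain carbon bound to a nitrogen on an aromatic ring; in this assay compound 3 gives 15500 nM, the higher of the two numbers shown, with compound 1 within the scatter of it, so no order between these two can be drawn.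

Compound 4 `COc1ccc(CNc2nc3cc(N)cc(N)c3nc2-c2ccccc2)cc1OC` is the next variant: 3,4-dimethoxyphenyl in place of 3,4-dichlorophenyl on a saturated chain carbon bound to a nitrogen on an aromatic ring. No measured step of this kind exists among the compounds shown. The change is expected to stay small, with the number for compound 4 estimated slightly higher than that of compound 3, a step of a 1.6-fold higher number from compound 3 to compound 4 (0.21 log units; within the scatter), but not beyond what the scatter of repeated measurements could cover. Compound 4 is therefore estimated at 25000 nM in this assay, with a range from 8000 nM to 80000 nM.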

Compound 4, concentration for 50% growth inhibition: 13200 nM
Compound 4: the middle estimate sits 1.9-fold (0.28 log units) above what was measured, and the stated range covers the measured number.
By their numbers in this assay, from the lowest: compounds 4, 1 and 3 (each within the scatter of the next).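

In this assay, among the compounds shown here, the first measured step at this position gives a 1.2-fold lower number from compound 3 to compound 4 (0.07 log units; within the scatter), so 3,4-dimethoxyphenyl in place of 3,4-dichlorophenyl on a saturated chain carbon bound to a nitrogen on an aromatic ring leaves no readable change. The exchange goes from 8 to 10 heavy atoms and from 0 to 2 hydrogen-bond acceptors, and neither difference comes with a step beyond the scatter in this pair. Both values in the step are numbers, whereas compound 2 gives only a limit: the limit of < 100000 nM in this assay, at which 1 of the 4 values shown sits.

One pair cannot show whether this position tolerates change in general. Going by these compounds, it remains open whether an amine or a carboxylic acid on the phenyl ring, or a longer chain to that ring, would move the number beyond the scatter.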